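The source may hold more compounds than are shown below. What is called first, only, known or untested is meant among the compounds shown, and "the series" means these compounds.

Compound 1 `CCCC(=O)OCSc1ccccc1C(=O)NCC(N)=O` is the reference point of this account. In an ADME assay on CEM-SS cells (Homo sapiens) for cytotoxicity, read by XTT assay, with a stated time of 6 days (a lower number here means that less compound is tolerated, a higher number that more compound is tolerated), compound 1 gives > 100 uM, which is a limit of the assay rather than a number; it stands at the limit of > 100 uM in this assay, at which 1 of the 3 values shown sits, the only one of the three measured values to do so. Compound 2 `CCCC(=O)OC[Se]c1ccccc1C(=O)NCC(N)=O` differs from compound 1 elsewhere on the shared core, and in this assay compound 2 gives 6.8 uM. Compound 3 `CCCC(=O)OC[Se]c1ccccc1C(=O)NCCC(N)=O` in this assay gives 10.5 uM. Among the compounds with values here, the single measured step, a 1.5-fold higher number from compound 2 to compound 3 (0.19 log units; within the scatter), covers carbamoylmethyl in place of carbamoyl on a saturated chain carbon bound to an amide-type nitrogen, and it stayed within the scatter. Compound 4 `CCCC(=O)OCSc1ccccc1C(=O)NCC(=O)NC` is the unmeasured member and differs from compound 1 by methyl in place of hydrogen on an amide-type nitrogen. Within the data shown here, no measured step alters an amide-type nitrogen itself, so the change from compound 2 to compound 3 bears on it only loosely, as the one example of a small alteration near that nitrogen, and that example moved nothing beyond the scatter. With compound 1 already at the limit, compound 4 is expected to remain there too. The step from compound 1 to compound 4 is therefore expected to be a number no higher from compound 1 to compound 4 (the limit leaves the size open). For compound 4 the estimate is 100 uM, between 50 uM and 200 uM.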

Compound 4, half-maximal toxic concentration: > 100 uM
Compound 4 gave a limit, no number; the forecaster's own chance of this, stated with the estimate: 75%; the middle value lies on the limit itself.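

In this assay compound 4 gives > 100 uM as a limit of the assay and not a number. Compound 1 also stands at a limit, so no step can be read between compound 1 and compound 4: the limit of > 100 uM in this assay, at which 2 of the 4 values shown sit. The compounds shown leave open whether methyl in place of hydrogen on an amide-type nitrogen changes the tolerated concentration at all.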